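The source may hold more compounds than are shown below. What is called first, only, known or untested is meant among the compounds shown, and "the series" means these compounds.

Compound 1 `COc1ccc(/C=C2/CN(C)/C(=N/c3ccc(Br)cc3)S2)cc1`: 7400 nM
Compound 2 `COc1ccc(/C=C2/CN(C)/C(=N/c3ccc([N+](=O)[O-])cc3)S2)cc1`: 9800 nM

In a functional assay on MCF7 cells (Homo sapiens) for antiproliferative activity, read by MTT assay, with a stated time of 72 h (a lower number here means a stronger inhibitor, a higher number a weaker inhibitor), compound 2 gives 9800 nM, which lies within the scatter of compound 1, so the two stand level. Compound 3 `COc1ccc(/C=C2/CN(C)/C(=N/c3ccc(Cl)cc3)S2)cc1` keeps the core of compound 2 but has chloro in place of nitro on an aromatic carbon, para to a large group: chloro in place of nitro on an aromatic carbon. Among the measured compounds shown here, no chloro compound has been measured yet, so the best guide is the one measured step, in which nitro replaces bromo at that same place: a 1.3-fold higher number from compound 1 to compound 2 (0.12 log units; within the scatter). That step stayed within the scatter, so no step beyond the scatter is expected in this assay for this new swap, although a single step is thin evidence. The expected step is a 1.2-fold lower number from compound 2 to compound 3 (0.09 log units; within the scatter). For compound 3 the estimated value is 8000 nM, with an expected range of 4000 nM to 16000 nM.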

Compound 3, half-maximal inhibitory concentration: 7600 nM
Estimate against measurement, compound 3: 1.1-fold (0.02 log units) above; the range from low to high includes it.
By their numbers in this assay, from the lowest: compounds 1, 3 and 2 (each within the scatter of the next).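

In this assay the swap to chloro on this aromatic carbon, para to a large group, gives a 1.3-fold lower number from compound 2 to compound 3 (0.11 log units; within the scatter) against nitro and a 1.0-fold higher number from compound 1 to compound 3 (0.01 log units; within the scatter) against bromo. Among the compounds shown here, with a third group in place, bromo, nitro and chloro all stand level, where the earlier pair offered only one comparison. Nitro brings three heavy atoms and two hydrogen-bond acceptors while chloro brings one heavy atom and no acceptor, yet these two compounds cannot be told apart in this assay.

On these data alone, whether an amine, a carboxylic acid or a longer chain such as butyl at this same place would also stay level remains open, as does the effect of changes elsewhere on the shared core. Nothing available gives a reason why these three groups stand level.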